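This account rests on a few compounds, and the source may have more. Where it says the series, first, only, none or still open, it means among the compounds named here.

Among the measured compounds shown here, compound 2, `CN1CCN(c2ccc(Nc3ncc(Cl)c(NCc4ccc(C(F)(F)F)cc4)n3)nc2)CC1`, is the only compound in this set with a numerical result: in a functional assay on Jurkat cells (Homo sapiens) for inhibition, read by CCK-8 assay, with a stated time of 48 h (a lower number here means a stronger inhibitor of growth, a higher number a weaker inhibitor of growth), compound 2 gives 7960 nM. Compound 1, `Cc1ccccc1Nc1nc(NC2CCCCC2)ncc1Cl`, is the other compound measured, and in this assay compound 1 reaches only the limit of the assay at > 100000 nM, which is not a number but a boundary (the limit of > 100000 nM in this assay, at which 1 of the 2 values shown sits). For the measured compounds named here, no step between two measured compounds is available, so the size of a change cannot be read from the data themselves. Compound 3, `Cc1cc(C)c(Nc2nc(Nc3ccc(N4CCN(C)CC4)cn3)ncc2Cl)c(C)c1`, is not yet measured. It differs from compound 2 in one place: 2,4,6-trimethylphenyl in place of 4-(trifluoromethyl)benzyl on a nitrogen on an aromatic ring. Given that compound 2 holds the only number and that no measured step guides the direction, compound 3 is expected to be weaker than compound 2, by a step of a 2.5-fold higher number from compound 2 to compound 3 (0.40 log units; beyond the scatter). The estimate for compound 3 in this assay is 20000 nM, with a range from 4000 nM to 100000 nM.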

Compound 3, concentration for 50% growth inhibition: 7600 nM
Beside the measured number, compound 3's estimate is 2.6-fold (0.42 log units) above it; the range from low to high includes it.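

Among the compounds shown here, the step of a 1.0-fold lower number from compound 2 to compound 3 (0.02 log units; within the scatter) is the first measured change at this position in this assay. On a nitrogen on an aromatic ring, 2,4,6-trimethylphenyl in place of 4-(trifluoromethyl)benzyl leaves the result within the scatter, so this assay does not tell these two groups apart, although one group contains fluorine and the other only carbon. Nothing measured here offers an explanation for this outcome.

The compounds shown leave open whether any group at this position would shift the number, since both groups tested carry a six-membered aromatic ring of carbon only; a carboxylic acid, an amine or a plain cyclohexyl group on the same nitrogen would test this. They also leave open whether the same exchange would give the same result on another core.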